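This account rests on a few compounds, and the source may have more. Where it says the series, first, only, none or still open, it means among the compounds named here.

Measured so far in a functional assay on Caco-2 cells (Homo sapiens) for inhibition, read by MTT assay, with a stated time of 72 h; a higher number here means a weaker inhibitor, a lower number a stronger inhibitor:

- compound 1 `CCCNC(=C\C(=O)/C=C/c1ccc(O)c(OC)c1)/C=C/c1ccc(O)c(OC)c1` | > 25000 nM
- compound 2 `COc1cc(/C=C/C(=O)CC(=O)/C=C/c2ccc(OC(C)=O)c(OC)c2)ccc1OC(C)=O` | > 25000 nM
- compound 3 `CCC(C)NC(=C\C(=O)/C=C/c1ccc(O)cc1)/C=C/c1ccc(O)cc1` | 9400 nM

Compound 1 gives only a limit, > 25000 nM, and not a number. Compound 2 also gives only a limit, > 25000 nM. Together they make up (the limit of > 25000 nM in this assay, at which 2 of the 3 values shown sit). Among the compounds with values here, compound 3 is the one compound with a true number, 9400 nM.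

Compound 4 `COc1cc(/C=C/C(=O)/C=C(/C=C/c2ccc(O)c(OC)c2)NCC(C)C)ccc1O` keeps the core of compound 1 and changes only the propylamino chain, which becomes isobutylamino: methyl in place of hydrogen on a saturated chain carbon bound to two saturated chain carbons. With no number for compound 1, the size of any step in this assay can only be expected, not worked out. A small step towards stronger inhibition is expected, and a step within the scatter would be no surprise. Compound 3 also carries a branched chain and gives 9400 nM, so a true number for compound 4 seems possible, although its core differs. The estimated step is an at least 1.2-fold lower number from compound 1 to compound 4 (0.09 log units; that floor lies within the scatter). For compound 4 the estimated value is 20000 nM, with an expected range of 9000 nM to 40000 nM.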

Compound 4, half-maximal inhibitory concentration: > 25000 nM
Compound 4 gave a limit, no number; the forecaster's own chance of this, stated with the estimate: 50%; middle value at least 1.2-fold (0.09 log units) away from the limit.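

Compound 4 gives > 25000 nM as a limit, not a number. Compound 1 is also only a limit, so no step from compound 1 to compound 4 can be read: the limit of > 25000 nM in this assay, at which 3 of the 4 values shown sit.

The compounds shown leave open how large any effect of changing propylamino to isobutylamino on the shared core is.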